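The source may report more compounds than this note shows. Statements on the series, on what has been measured and on what is new or still open speak of the compounds shown alone.

In a functional assay on DU-145 cells (Homo sapiens) for inhibition, read by trypan blue exclusion, with a stated time of 96 h (on this read-out lower numbers stand for stronger inhibition of growth and higher numbers for weaker inhibition of growth), compound 1 `COc1ccc(C(=O)/C(=C\c2ccc(O)c([N+](=O)[O-])c2)SCc2ccc(Br)cc2)cc1` gives 10000 nM. Compound 2 `O=C(/C(=C\c1ccc(O)c([N+](=O)[O-])c1)SCc1ccc(Br)cc1)c1ccc(O)cc1O` gives only a limit in this assay, > 100000 nM. Compound 3 `O=C(/C(=C\c1ccc(O)c([N+](=O)[O-])c1)SCc1ccc(Br)cc1)c1c(F)c(F)c(F)c(F)c1F` gives 10000 nM in this assay, so compound 3 sits level with compound 1 at the digits shown. Across these three compounds only the group on the carbonyl carbon changes: the step of an at least 10-fold higher number from compound 1 to compound 2 (1.00 log units; beyond the scatter) was an at least 10-fold higher number from compound 1 to compound 2 (1.00 log units; beyond the scatter), the step of no change at the digits printed from compound 1 to compound 3 (within the scatter) was no change at the digits printed from compound 1 to compound 3 (within the scatter), and the step of an at least 10-fold lower number from compound 2 to compound 3 (1.00 log units; beyond the scatter) was an at least 10-fold lower number from compound 2 to compound 3 (1.00 log units; beyond the scatter). Compound 4 `N#Cc1ccc(C(=O)/C(=C\c2ccc(O)c([N+](=O)[O-])c2)SCc2ccc(Br)cc2)cc1` differs from compound 3 at the same place: 4-cyanophenyl in place of 2,3,4,5,6-pentafluorophenyl on a carbonyl carbon. For the measured compounds named here, the two steps that exchanged one group on the carbonyl carbon for another without introducing hydroxyl groups left the number unchanged within the scatter, while the one step that introduced 2,4-dihydroxyphenyl at this position pushed the number to a limit. The change to 4-cyanophenyl brings no hydroxyl, so no step beyond the scatter is expected. Compound 4 is therefore estimated at 10000 nM, between 3000 nM and 40000 nM, which means an expected step of no change at the digits printed from compound 3 to compound 4 (within the scatter).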

Compound 4, concentration for 50% growth inhibition: 10000 nM
The estimate for compound 4 equals the measured number at the digits printed; measured number inside the range.
By their numbers in this assay, from the lowest: compounds 1, 3 and 4 (each within the scatter of the next). At a limit, above all of these: compound 2.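

In this assay the change to 4-cyanophenyl on the carbonyl carbon gives no change at the digits printed from compound 3 to compound 4 (within the scatter) and also no change at the digits printed from compound 1 to compound 4 (within the scatter) and so a third group, this one carrying a nitrile, joins 4-methoxyphenyl and 2,3,4,5,6-pentafluorophenyl at one level. Among the compounds shown, 2,4-dihydroxyphenyl is now the only group that stands apart at this position, with an at least 10-fold lower number from compound 2 to compound 4 (1.00 log units; beyond the scatter) as the printed gap. Compound 2 remains at a limit: the limit of > 100000 nM in this assay, at which 1 of the 4 values shown sits.

Going by these compounds, whether a single hydroxyl group on that phenyl ring is enough to produce the same loss stays open, and so does the effect of an amine or a carboxylic acid there. Also open, on these data alone, is whether any group on the carbonyl carbon can bring the number lower than the level shared by compounds 1, 3 and 4.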